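The compounds below may be only part of what the source reports. "The series", "measured", "known", "first", "only" and "open" are said of these compounds alone.

In a functional assay on NCI-H1299 cells (Homo sapiens) for antiproliferative activity, read by CCK-8 assay, with a stated time of 72 h (on this read-out lower numbers stand for stronger inhibition and higher numbers for weaker inhibition), compound 1 (`Nc1ccccc1NC(=O)c1ccc(CSC(=S)N2CCN(c3ccccc3)CC2)cc1`) gives 610 nM and compound 2 (`Nc1ccccc1NC(=O)c1ccc(CSC(=S)N2CCc3ccccc32)cc1`) gives 2900 nM as the higher of the two numbers, a gap beyond the scatter. For the measured compounds named here, no single-place step links these two compounds, so the gap cannot be assigned to any one group. Compound 3 (`Nc1ccccc1NC(=O)c1ccc(CSC(=S)N2CCc3cc(Cl)ccc32)cc1`) departs from compound 2 at one place (chloro in place of hydrogen on an aromatic carbon): chloro in place of hydrogen on an aromatic carbon, with 2,3-dihydro-1H-indol-1-yl becoming 5-chloro-2,3-dihydro-1H-indol-1-yl. Going by the values given here, no measured pair shows this change, so the expectation rests on little. A small move toward a lower number in this assay is expected, probably not beyond the scatter. The estimated step is a 1.6-fold lower number from compound 2 to compound 3 (0.21 log units; within the scatter) on this read-out. Compound 3 is expected at 1800 nM with an estimated range from 700 nM to 4500 nM for now.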

Compound 3, half-maximal inhibitory concentration: 3280 nM
For compound 3 the middle estimate is 1.8-fold (0.26 log units) below the measured one, and the stated range covers the measured number.
By their numbers in this assay, from the lowest: compound 1; then compounds 2 and 3 (each within the scatter of the next).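

In this assay, for the compounds shown here, chloro in place of hydrogen on an aromatic carbon, turning 2,3-dihydro-1H-indol-1-yl into 5-chloro-2,3-dihydro-1H-indol-1-yl, gives a 1.1-fold higher number from compound 2 to compound 3 (0.05 log units; within the scatter) and provides the first single-place step. On this read-out, the position accepts a chloro with no change that can be told from the scatter, though this is one substituent at one position. No measured evidence on the compounds bears on this result.

As far as these compounds go, whether an amine, a methoxy group or a carboxylic acid at this carbon would also leave the number unchanged remains open, as does the effect of chloro on the other carbons of this six-membered aromatic ring. Compound 1 still has no single-place link to compound 2 or compound 3, so its separation from them cannot be assigned to any one group.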